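Swapping the diol of compound 3 for a carboxymethyl group

The source may report more compounds than this note shows. Statements on the series, on what has been measured and on what is new or still open speak of the compounds shown alone.

In an ADME assay on HepG2 2.2.15 cells (Homo sapiens) for cytotoxicity, read by MTT assay, with a stated time of 8 days (a higher number here means that more compound is tolerated, a lower number that less compound is tolerated), compound 1 `N#Cc1ccc(Cn2nc(-c3cc(Cl)c(NCCO)nc3F)c3ccccc3c2=O)cc1` gives 32100 nM as its half-maximal cytotoxic concentration. In this assay compound 2 `N#Cc1ccc(Cn2nc(-c3cc(Cl)c(NC[C@H](O)CO)nc3F)c3ccccc3c2=O)cc1` gives > 100000 nM and this is a limit, not a number. In this assay compound 3 `N#Cc1ccc(Cn2nc(-c3cc(Cl)c(NC[C@@H](O)CO)nc3F)c3ccccc3c2=O)cc1` gives > 100000 nM and this too is a limit, not a number. Compound 3 therefore has no exact value, and it shares its limit with compound 2.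

Hydroxymethyl in place of hydrogen on the chain gives an at least 3.1-fold higher number from compound 1 to compound 2 (0.49 log units; beyond the scatter) and also an at least 3.1-fold higher number from compound 1 to compound 3 (0.49 log units; beyond the scatter) in the other configuration. Configuration alone gives a step that the two limits leave unreadable from compound 2 to compound 3 and so tells nothing further.

Compound 4 `N#Cc1ccc(Cn2nc(-c3cc(Cl)c(NCCC(=O)O)nc3F)c3ccccc3c2=O)cc1` puts carboxymethyl in place of 1,2-dihydroxyethyl on a saturated chain carbon bound to a nitrogen on an aromatic ring, as carboxymethyl in place of 1,2-dihydroxyethyl on a saturated chain carbon bound to a nitrogen on an aromatic ring sets out. Within the data shown here, no measured step makes this exact swap, so the two hydroxymethyl steps are the nearest guide, and both are modest and known only as bounds. A modest fall in the tolerated concentration is therefore expected, or none that can be read if the limit returns. The expected move is an at least 1.2-fold lower number from compound 3 to compound 4 (0.09 log units; that floor lies within the scatter) and it is only an estimate. In this assay the expected value for compound 4 is 80000 nM (estimated range 30000 nM to 150000 nM).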

Compound 4, half-maximal cytotoxic concentration: > 100000 nM
Compound 4 gave a limit, no number (the forecaster's own chance of this, stated with the estimate: 50%); at least 1.2-fold (0.09 log units) between middle value and limit.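

In this assay compound 4 gives > 100000 nM, which is a limit and not a number. The earlier compounds shown here tied the higher number to the 1,2-dihydroxyethyl group, but carboxy in place of hydroxy on the chain also gives an at least 3.1-fold higher number from compound 1 to compound 4 (0.49 log units; beyond the scatter), so at this position that rise does not depend on the 1,2-dihydroxyethyl group or on its defined stereocentre. The steps among compounds 2, 3 and 4 cannot be read, because all three sit at the same limit: the limit of > 100000 nM in this assay, at which 3 of the 4 values shown sit.

As far as these compounds go, whether compounds 2, 3 and 4 truly differ from one another therefore stays open, and carboxymethyl can be called neither better nor worse tolerated than 1,2-dihydroxyethyl. Also open, from the compounds shown here alone, is whether a chain ending in an amine, or a longer chain carrying the carboxylic acid, would be tolerated as well as compound 4 or would come back towards compound 1, which gives 32100 nM.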